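This account rests on a few compounds, and the source may have more. Where it says the series, first, only, none or still open, it means among the compounds named here.

Working notes on the series. Compound 1 `CS(=O)(=O)Nc1ccc2c(c1)S(=O)(=O)N=C(C1=C(O)C3CCCC3N(CCC3CC3)C1=O)N2` carries a 2-cyclopropylethyl group on the amide-type nitrogen in the ring of the shared core. In an in vitro ADME assay on microsomes from liver (Homo sapiens) for metabolic stability (on this read-out lower numbers stand for a shorter-lived compound and higher numbers for a longer-lived compound), compound 1 gives 0.417 h. Compound 2 `CC(C)(C)CCN1C(=O)C(C2=NS(=O)(=O)c3cc(NS(C)(=O)=O)ccc3N2)=C(O)C2CCCCC21` in this assay gives 0.267 h, and the two numbers sit within the usual scatter of each other, so no order between compound 1 and compound 2 is claimed. Compound 3 `CS(=O)(=O)Nc1ccc2c(c1)S(=O)(=O)N=C(C1=C(O)[C@H]3CCC[C@H]3N(Cc3ccc(F)c(Cl)c3)C1=O)N2` in this assay gives > 1 h, which is a limit of the assay and not a number (the limit of > 1 h in this assay, at which 1 of the 3 values shown sits). Compound 4 `CS(=O)(=O)Nc1ccc2c(c1)S(=O)(=O)N=C(C1=C(O)C3CCCC3N(Cc3ccc(Cl)cc3)C1=O)N2` has not been measured; it differs from compound 1 by 4-chlorophenyl in place of cyclopropylmethyl on a saturated chain carbon bound to an amide-type nitrogen in a ring. Among the compounds with values here, no step between measured compounds covers this exact change, so any expectation rests on compound 3 with its limit and on compound 2 with its number. The expected step from compound 1 to compound 4 is a 2.2-fold higher number from compound 1 to compound 4 (0.33 log units; beyond the scatter), upward and at the border of the scatter. Compound 4 is expected to give 0.9 h, with a range from 0.4 h to 2 h. A limit rather than a number is a real possibility for compound 4.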

Compound 4, half-life: > 1 h
Compound 4: a limit, no number; the forecaster's own chance of this, stated with the estimate: 40%; middle value at least 1.1-fold (0.04 log units) away from the limit.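

Within the data shown here, at the saturated chain carbon bound to an amide-type nitrogen in a ring, the earlier compounds offered no comparison in one place, whereas 4-chlorophenyl in place of cyclopropylmethyl now gives in this assay an at least 2.3-fold higher number from compound 1 to compound 4 (0.37 log units; beyond the scatter) as the first such step. Compound 4 gives > 1 h which is a limit of the assay and not a number, so this step fixes only a lower bound on the change and not its size. The top of the measurable range now holds more than one compound of the series: the limit of > 1 h in this assay, at which 2 of the 4 values shown sit.

The compounds shown leave open whether the step belongs to the chlorine or to the aromatic ring, as a plain benzyl group is not among them. As far as these compounds go, how an amine or a carboxylic acid at this position would read also stays open.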